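This account rests on a few compounds, and the source may have more. Where it says the series, first, only, none or still open, it means among the compounds named here.

Measured so far:
compound 1 `CCCCc1ccc(-c2cc(=O)c3c(o2)C(CC)(CC)C(=O)C(CC)=C3O)cc1`: 37 uM
compound 2 `CCC1=C(O)c2c(oc(-c3ccc(C(F)(F)F)cc3)cc2=O)C(CC)(CC)C1=O`: 10.4 uM
compound 3 `CCC1=C(O)c2c(oc(-c3ccc(F)cc3)cc2=O)C(CC)(CC)C1=O`: 1.85 uM

In a functional assay on KBVIN cells (Homo sapiens) for antiproliferative activity, read by sulforhodamine B assay, with a stated time of 3 days (a higher number here means that more compound is needed for the effect, a lower number that less compound is needed), compound 3 stands lowest of the three, with a 5.6-fold lower number from compound 2 to compound 3 (0.75 log units; beyond the scatter) and a 20-fold lower number from compound 1 to compound 3 (1.30 log units; beyond the scatter) both beyond the scatter. Compound 4 `CCC1=C(O)c2c(oc(-c3ccc(O)c(O)c3)cc2=O)C(CC)(CC)C1=O` differs from compound 3 by 3,4-dihydroxyphenyl in place of 4-fluorophenyl on an aromatic carbon. Among the compounds with values here, no measured step involves a hydroxyl group on this aryl ring; the only steps that bear on the position are a 20-fold lower number from compound 1 to compound 3 (1.30 log units; beyond the scatter) and a 5.6-fold lower number from compound 2 to compound 3 (0.75 log units; beyond the scatter), which show the numbers moving as the group on that aromatic carbon is exchanged, without telling how a 3,4-dihydroxyphenyl will behave. A modest step toward a higher number is therefore expected, a 2.4-fold higher number from compound 3 to compound 4 (0.39 log units; beyond the scatter), with wide uncertainty. For compound 4 the expected value in this assay is 4.5 uM, with a range from 1.2 uM to 18 uM.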

Compound 4, concentration for half-maximal effect: 5.41 uM
Beside the measured number, compound 4's estimate is 1.2-fold (0.08 log units) below it; low and high end bracket the measured number.
By their numbers in this assay, from the lowest: compound 3; then compounds 4 and 2 (each within the scatter of the next); then compound 1.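

In this assay, 3,4-dihydroxyphenyl in place of 4-fluorophenyl gives a 2.9-fold higher number from compound 3 to compound 4 (0.47 log units; beyond the scatter), so adding hydrogen-bond donors to this aryl ring costs only a modest step from the best number in the series. Compound 4 at 5.41 uM still stands well under compound 1 at 37 uM, which shows that this position accepts hydroxyl groups as well as halogen and alkyl groups. Nothing at hand explains the size of this step.

Open, on these data alone, is whether the loss of fluoro or the gain of the two hydroxyl groups drives the step. Also open, as far as these compounds go, is how a single hydroxyl, a methoxy group, an amine or a carboxylic acid on this ring would behave.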